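The compounds below may be only part of what the source reports. "The series", "measured", "known", "first", "only" and "open" are said of these compounds alone.

Working notes on the series. Among the measured compounds shown here, in a functional assay on the whole organism with Rattus norvegicus as the target (a higher number here means that more compound is needed for the effect, a lower number that less compound is needed), three compounds carry numbers so far. Compound 1 `C/N=C(/NC#N)NCCCCCn1nc(-c2ccccc2)ccc1=O` gives 76.2 mg/kg in this assay. Compound 2 `CC/N=C(/NC#N)NCCCn1nc(-c2ccccc2)ccc1=O` gives 88.5 mg/kg in this assay, the highest of the three numbers; the nearest to it is compound 1, and that gap lies within the usual scatter, so no order between compound 1 and compound 2 is claimed. The furthest from compound 2 is compound 3 `NC(=O)SCCCCCN1NC=CC=C1c1ccccc1`, which in this assay gives 18.3 mg/kg, a gap beyond the scatter. No two of the measured compounds differ in only one place, so no single-point step can be read from them.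

Compound 4 `CC/N=C(\S)NCCCCn1nc(-c2ccccc2)ccc1=O` has not yet been measured. It differs from compound 2 by a group of 7 heavy atoms (4 carbon, 2 nitrogen, 1 sulfur; no ring) in place of a group of 8 heavy atoms (4 carbon, 4 nitrogen; no ring), on a saturated chain carbon, three bonds along the chain from an aromatic nitrogen. The shared core is kept. For the measured compounds named here, no measured pair isolates this change; compound 3, the one measured compound that also carries sulfur, differs from compound 2 in its chain and its core as well, so its lower number tells nothing about the exchange alone. The step from compound 2 to compound 4 is expected to be a 1.8-fold lower number from compound 2 to compound 4 (0.25 log units; within the scatter), toward a lower number, of a size near the edge of the scatter. Compound 4 is expected to give about 50 mg/kg in this assay, with an estimated range from 20 mg/kg to 120 mg/kg.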

Compound 4, dose for half-maximal effect: 19.8 mg/kg
The estimate for compound 4 lay 2.5-fold (0.40 log units) above the measured number, and the stated range ends above it.
By their numbers in this assay, from the lowest: compounds 3 and 4 (each within the scatter of the next); then compounds 1 and 2 (each within the scatter of the next).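

In this assay this position now has its first readable steps. The group of 7 heavy atoms (4 carbon, 2 nitrogen, 1 sulfur; no ring) in place of the group of 8 heavy atoms (4 carbon, 4 nitrogen; no ring) gives a 4.5-fold lower number from compound 2 to compound 4 (0.65 log units; beyond the scatter), and a sulfur-bearing group in place of that same group of 8 gives a 3.8-fold lower number from compound 1 to compound 4 (0.59 log units; beyond the scatter); both run the same way and both lie beyond the scatter, so a sulfur-bearing group at this place goes with a lower number from either nitrile-bearing starting point, a link that compound 3 could not show. Nothing measured here bears on why the number falls.

The compounds shown leave open how much of each step belongs to the sulfur-bearing group alone and how much to the chain, as the two steps are read at different places on it. From the compounds shown here alone, how an amine, a carboxylic acid, a urea with oxygen in place of the sulfur, or a longer chain carrying the same sulfur-bearing group would read at this position also stays open.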